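The source may report more compounds than this note shows. Statements on the series, on what has been measured and on what is new or still open speak of the compounds shown alone.

Compound 1 `CC1=C(C(=O)NC(C)C)C(c2ccco2)NC(=O)N1` gives 2% in an assay on membranes from HEK293 cells for displacement of a labelled ligand from adenosine receptor A2b (Homo sapiens), read by scintillation counting, with a stated time of 30 min, tested at 1 uM; on this read-out higher numbers stand for more inhibition at the one concentration tested (going by the name of the read-out) and lower numbers for less inhibition. Compound 2 `CCSC(=O)C1=C(C)NC(=O)NC1c1ccco1` gives 29%. Compound 3 `CC1=C(C(=O)SC(C)C)C(c2ccco2)NC(=O)N1` gives 22%.

Compound 3 stands second highest of the three numbers. Its nearest neighbour is compound 2, and the change between them, a number 7 percentage points lower from compound 2 to compound 3 (within the scatter), lies within the scatter. Its furthest is compound 1, and a number 20 percentage points higher from compound 1 to compound 3 (beyond the scatter) lies beyond the scatter, as does a number 27 percentage points higher from compound 1 to compound 2 (beyond the scatter).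

Compound 4 `CC1=C(C(=O)OC2CCCCC2)C(c2ccco2)NC(=O)N1` has not yet been measured. It differs from compound 3 in one place: cyclohexyloxy in place of isopropylsulfanyl on a carbonyl carbon. For the measured compounds named here, no measured step exchanges a sulfur-linked group for an oxygen-linked one, so no step bears on this change directly. The two steps that replace isopropylamino on the carbonyl carbon, a number 27 percentage points higher from compound 1 to compound 2 (beyond the scatter) and a number 20 percentage points higher from compound 1 to compound 3 (beyond the scatter), show that what sits on that carbonyl carbon can move the number modestly, while a number 7 percentage points lower from compound 2 to compound 3 (within the scatter) shows that the size of the group on the sulfur changed little. An oxygen-linked cyclohexyl group is therefore expected to stay in the lower part of the range seen so far, with the step of a number 7 percentage points lower from compound 3 to compound 4 (within the scatter) expected to be within the scatter or slightly downward. Compound 4 is estimated at 15%, between 0% and 38%.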

Compound 4, a percentage reported as inhibition, at one concentration (the size of the read-out at that concentration, not a potency): 1%
For compound 4 the middle estimate is 14 percentage points above the measured one; the measured number falls inside the stated range.
By their numbers in this assay, from the lowest: compounds 4 and 1 (each within the scatter of the next); then compounds 3 and 2 (each within the scatter of the next).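

Read in this assay the exchange of a sulfur-linked group for cyclohexyloxy on the carbonyl carbon is not neutral, since the result is a number 21 percentage points lower from compound 3 to compound 4 (beyond the scatter) and a number 28 percentage points lower from compound 2 to compound 4 (beyond the scatter) for the two sulfur-linked compounds, both modest steps. With a number 1 percentage points lower from compound 1 to compound 4 (within the scatter) the cyclohexyloxy and isopropylamino groups cannot be told apart at this position, so among these four compounds only the ethylsulfanyl and isopropylsulfanyl groups of compound 2 and compound 3 stand clear of that low level. The step from compound 3 to compound 4 changes the linking atom and the group it carries together, and no evidence at hand bears on what lies behind the fall.

Still open, as far as these compounds go, is whether the linking oxygen or the cyclohexyl ring accounts for the lower number, a question that an isopropyloxy group and a cyclohexylsulfanyl group on the same carbonyl carbon would separate. Also open, from the compounds shown here alone, is whether a small ethoxy group, a free carboxylic acid or a cyclohexylamino group at this place would stay at the low level or come closer to the sulfur-linked compounds.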